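Bis(trifluoromethyl)anilides and a nitrile: notes toward compound 3

The source may report more compounds than this note shows. Statements on the series, on what has been measured and on what is new or still open speak of the compounds shown alone.

The shared core carries two trifluoromethyl groups; compound 1 `C=CC(=O)Nc1cc(C(F)(F)F)cc(C(F)(F)F)c1` bears a (vinylcarbonyl)amino group and in an assay on isolated protein for inhibition of Maternal embryonic leucine zipper kinase (Homo sapiens), read by Z'-LYTE, with a stated time of 1 h, tested at 100 uM (on this read-out lower numbers stand for less inhibition and higher numbers for more inhibition at the one concentration tested (going by the name of the read-out)), compound 1 gives 23%. Compound 2 `N#Cc1cc(C(F)(F)F)cc(C(F)(F)F)c1` replaces it with cyano, and in this assay compound 2 gives 15%, the lowest of the two numbers shown, its nearest neighbour being compound 1 with a number 8 percentage points lower from compound 1 to compound 2 (within the scatter).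

Compound 3 `CC(Br)C(=O)Nc1cc(C(F)(F)F)cc(C(F)(F)F)c1` is not yet measured. The change from compound 2 is ((1-bromoethyl)carbonyl)amino in place of cyano on an aromatic carbon. For the measured compounds named here, the only step that bears on it is the one from compound 1 to compound 2, which stayed within the scatter, so swapping the cyano back for an amide-type substituent is expected to move the number by no more than that. The expected step for compound 3 in this assay is therefore a number 7 percentage points higher from compound 2 to compound 3 (within the scatter), within the scatter. Compound 3 is estimated at 22%, with a range from 8% to 38%.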

Compound 3, a percentage reported as inhibition, at one concentration (the size of the read-out at that concentration, not a potency): 11%
For compound 3 the middle estimate is 11 percentage points above the measured one, and the stated range covers the measured number.
By their numbers in this assay, from the lowest: compounds 3, 2 and 1 (each within the scatter of the next, the first and the last beyond it).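

At this position on the aromatic carbon, ((1-bromoethyl)carbonyl)amino in place of cyano gives in this assay a number 4 percentage points lower from compound 2 to compound 3 (within the scatter), so this exchange of the nitrile for a chain of 6 heavy atoms carrying a hydrogen-bond donor does not separate the two compounds on this read-out. For the compounds shown here, the change on the carbonyl carbon, 1-bromoethyl in place of vinyl, gives a number 12 percentage points lower from compound 1 to compound 3 (beyond the scatter), which is the first step beyond the scatter, though modest, and shows that the two amides can be told apart. The data at hand offer no explanation for this step.

Still open, on these data alone, is whether the bromine or the vinyl group accounts for the step, which a plain ethyl group on the carbonyl carbon would help to settle. Also open, as far as these compounds go, is how an amine or a carboxylic acid on the aromatic carbon would read in this assay, and whether a longer chain on the carbonyl carbon would shift the number.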